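This account rests on a few compounds, and the source may have more. Where it says the series, first, only, none or still open, it means among the compounds named here.

Within the data shown here, in an in vitro ADME assay on microsomes from liver (Simiiformes) (a higher number here means that the compound lasts longer, a lower number that the compound disappears faster), compound 2 (`Cc1cc(CCCOc2c(C)cc(-c3noc(CC(F)(F)F)n3)cc2C)on1`) gives 0.533 h, the only true number among the three compounds measured so far. Compound 1 (`Cc1cc(-c2noc(C3CC3)n2)cc(C)c1OCCCc1cc(C2CC2)no1`) gives > 2.5 h, which is a limit of the assay and not a number. Compound 3 (`CCOc1cc(CCCOc2c(C)cc(-c3noc(C4CC4)n3)cc2C)on1`) gives > 2.5 h, which is again a limit. The picture so far is therefore defined largely by the limit of > 2.5 h in this assay, at which 2 of the 3 values shown sit.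

Compound 4 (`Cc1cc(CCCOc2c(C)cc(-c3noc(C(N)=O)n3)cc2C)on1`) departs from compound 2 through a single change, carbamoyl in place of 2,2,2-trifluoroethyl on an aromatic carbon.

Among the measured compounds shown here, only one measured step is available for comparison, a step that the two limits leave unreadable from compound 1 to compound 3. That step places ethoxy in place of cyclopropyl, does not touch the group that changes here, and offers no size to carry over. For the measured compounds named here, no measured step replaces 2,2,2-trifluoroethyl, so the data indicate neither a size nor a direction for this change. The expectation therefore stays anchored on compound 2 at 0.533 h, with no shift beyond the usual scatter foreseen in this assay.

The expected change is a 1.1-fold higher number from compound 2 to compound 4 (0.05 log units; within the scatter), an estimate that carries wide uncertainty. For compound 4 the estimated half-life is 0.6 h, with an expected range from 0.2 h to 1.8 h.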

Compound 4, half-life: 2.3 h
The estimate for compound 4 lay 3.8-fold (0.58 log units) below the measured number, outside the stated range (above it).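

Carbamoyl in place of 2,2,2-trifluoroethyl gives a 4.3-fold higher number from compound 2 to compound 4 (0.64 log units; beyond the scatter), so the group on this aromatic carbon, next to the ring nitrogen and the ring oxygen, clearly bears on the half-life in this assay. Among these compounds, the earlier compounds could not show this, as their only step between compounds differing in one place lay elsewhere in the structure and had no readable size. The step also gives this position a direction for this one exchange, but it swaps 2,2,2-trifluoroethyl for a smaller group with a hydrogen-bond donor and acceptor in a single move, so it does not tell which of these differences carries the gain.

The compounds shown leave open whether a nitrile, a carboxylic acid, an amine or a longer alkyl chain on the same carbon would follow carbamoyl or stay with 2,2,2-trifluoroethyl. They also leave open how far any such group could extend the half-life, and a gain beyond that of compound 4 may be hard to size in this assay: the limit of > 2.5 h in this assay, at which 2 of the 4 values shown sit.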